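The compounds below may be only part of what the source reports. "The series", "measured", "known", "first", "only" and "open" are said of these compounds alone.

Values measured in a functional assay on QGY-7703 cells (Homo sapiens) for cytotoxicity, read by MTT assay, with a stated time of 24 h; on this read-out lower numbers stand for stronger inhibition and higher numbers for weaker inhibition:

- compound 1 `CN1C/C(=C\c2ccncc2)C(=O)/C(=C/c2ccccc2C(F)(F)F)C1`: 4500 nM
- compound 2 `O=C1/C(=C/c2ccncc2)CN(S(=O)(=O)c2ccc([N+](=O)[O-])cc2)C/C1=C\c1ccccc1F`: 8800 nM
- compound 3 `O=C1/C(=C/c2ccncc2)CN(S(=O)(=O)c2ccccc2)C/C1=C\c1ccccc1C(F)(F)F`: 6210 nM

The three numbers lie close together, and compound 3 sits within the usual scatter of both compound 1 and compound 2, so no order can be read among them. The next compound, compound 4 `O=C1/C(=C/c2ccncc2)CN(S(=O)(=O)c2ccc([N+](=O)[O-])cc2)C/C1=C\c1ccccc1C(F)(F)F`, differs from compound 3 in one place: nitro in place of hydrogen on an aromatic carbon. This nitro replaces hydrogen on an aromatic carbon, para to a large group, turning phenylsulfonyl into (4-nitrophenyl)sulfonyl.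

For the measured compounds named here, no measured step shows this exact change. The nearest step changes the same ring nitrogen, a 1.4-fold higher number from compound 1 to compound 3 (0.14 log units; within the scatter), and so stays small. Compound 2 already carries the (4-nitrophenyl)sulfonyl group and gives 8800 nM, though it differs elsewhere. On this evidence, no shift beyond the scatter is expected in this assay. The estimated step is a 1.1-fold higher number from compound 3 to compound 4 (0.04 log units; within the scatter). For compound 4 the expected value is 6800 nM, with an estimated range of 3500 nM to 13000 nM.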

Compound 4, half-maximal inhibitory concentration: 9730 nM
For compound 4 the middle estimate is 1.4-fold (0.16 log units) below the measured one, and the stated range covers the measured number.
By their numbers in this assay, from the lowest: compounds 1, 3, 2 and 4 (each within the scatter of the next, the first and the last beyond it).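

In this assay nitro in place of hydrogen on the aromatic carbon para to a large group gives a 1.6-fold higher number from compound 3 to compound 4 (0.20 log units; within the scatter) and so does not clearly move the number, while trifluoromethyl in place of fluoro on an aromatic carbon, with the nitro group present in both compounds, gives a 1.1-fold higher number from compound 2 to compound 4 (0.04 log units; within the scatter) and is equally unresolved. For the compounds shown here, the full replacement on the ring nitrogen, (4-nitrophenyl)sulfonyl in place of methyl, gives a 2.2-fold higher number from compound 1 to compound 4 (0.33 log units; beyond the scatter) and is the first step here beyond the scatter, though only modestly, toward weaker inhibition. Nothing available explains this small shift.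

From the compounds shown here alone, whether an amine or a carboxylic acid on that same aromatic carbon would change the number more remains open. So does whether a longer chain on the ring nitrogen would behave like methyl or like the sulfonyl groups.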